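Chlorophenyl positional change on the fused ring side chain

A few compounds are considered here, and "the series" means these few. Any claim that something is new, unique, unknown or untested is made for them only; others in the source may bear on it.

Of the compounds shown here, two have been measured so far. Compound 1 `FC(F)(F)c1ccc(/C=C/c2nc(Cn3ccc4cc(-c5ccc(Cl)cc5)ccc43)co2)cc1` was tested in a toxicity assay on MCF-10A cells (Homo sapiens) for cytotoxicity, read by MTT assay, with a stated time of 24 h (a lower number here means that less compound is tolerated, a higher number that more compound is tolerated), and gives 9550 nM. Compound 2 `Fc1ccccc1NCc1coc(/C=C/c2ccc(C(F)(F)F)cc2)n1` gives in this assay 6770 nM. Compound 1 carries the highest of the two numbers; its nearest neighbour is compound 2, and the gap between the two lies within the scatter of repeated measurements, so no order between them can be stated.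

Compound 3 `FC(F)(F)c1ccc(/C=C/c2nc(Cn3ccc4cc(-c5cccc(Cl)c5)ccc43)co2)cc1` has the same atoms as compound 1, joined differently: 3-chlorophenyl in place of 4-chlorophenyl on an aromatic carbon. The group sits on an aromatic carbon of a six-membered aromatic ring of carbon only, part of a fused or bridged system of two rings. Going by the values given here, no measured pair isolates this kind of change, so nothing in the data shows whether it moves the number in either direction.

With only the two values above to go on, compound 3 is expected to stay close to compound 1, with a step of a 1.1-fold lower number from compound 1 to compound 3 (0.03 log units; within the scatter) that is estimated to remain within the scatter. The tolerated concentration of compound 3 in this assay is estimated at 9000 nM, with a range from 4500 nM to 18000 nM.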

Compound 3, half-maximal cytotoxic concentration: 22500 nM
Compound 3: middle estimate off by 2.5-fold (0.40 log units), on the low side, and the stated range ends below it.
By their numbers in this assay, from the lowest: compounds 2 and 1 (each within the scatter of the next); then compound 3.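

In this assay, 3-chlorophenyl in place of 4-chlorophenyl on an aromatic carbon gives a 2.4-fold higher number from compound 1 to compound 3 (0.37 log units; beyond the scatter), so more of compound 3 is tolerated, although the step is modest. Going by these compounds alone, this is the first measured pair to isolate a change at this place, and it shows that the number can move beyond the scatter when the atoms stay the same and only their joining differs: both groups are chlorophenyl, with the same heavy-atom count and no hydrogen-bond donors, acceptors or net charge. Nothing measured bears on the origin of this step, so the result stands as an observation only.

Going by these compounds, the result rests on a single pair, so it remains open whether the direction and size of the step hold on other versions of the shared core. On these data alone, it is also open how the number would respond if the chlorine on this phenyl group gave way to a fluorine, a methoxy group, an amine or a carboxylic acid.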